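Swapping the Aryl Ether End Group in Cyanoguanidines

The source may hold more compounds than are shown below. What is called first, only, known or untested is meant among the compounds shown, and "the series" means these compounds.

Measured compounds in a functional assay on NSCLC cells (Homo sapiens) for antiproliferative activity; on this read-out lower numbers stand for stronger inhibition and higher numbers for weaker inhibition:
Compound 1, `N#CN(C(=N)NCCCCCOc1ccccc1)c1ccncc1`: 44 nM
Compound 2, `N#CN/C(=N\CCCCCCOc1ccccc1Cl)Nc1ccncc1`: 0.6 nM

Of the compounds shown here, two have been measured in this assay. Compound 2 gives the lower of the two numbers, and the gap to compound 1 lies well beyond the usual scatter of this kind of measurement, so compound 2 is clearly the stronger inhibitor of the pair. Since the two differ from each other in more than one place, the values show only this overall contrast and do not attribute it to any single change.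

Compound 3, `N#CN/C(=N\CCCCCCOc1ccc([N+](=O)[O-])cc1)Nc1ccncc1`, has not yet been measured. It differs from compound 2 in one place only: 4-nitrophenyl in place of 2-chlorophenyl on an oxygen on a saturated carbon. Among the compounds with values here, no measured pair of compounds shows this kind of exchange, so there is no reference step to lean on. Given how low compound 2 already stands, a modest weakening seems the more likely outcome, though a step within the scatter cannot be excluded. The step from compound 2 to compound 3 is expected to be a 3.3-fold higher number from compound 2 to compound 3 (0.52 log units; beyond the scatter). Compound 3 is estimated to give about 2 nM in this assay, within a range from 0.4 nM to 12 nM.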

Compound 3, half-maximal inhibitory concentration: 52 nM
Beside the measured number, compound 3's estimate is 26-fold (1.41 log units) below it; the whole stated range lies below it.
By their numbers in this assay, from the lowest: compound 2; then compounds 1 and 3 (each within the scatter of the next).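

Changing only the group on the oxygen, with 4-nitrophenyl in place of 2-chlorophenyl, gives an 87-fold higher number from compound 2 to compound 3 (1.94 log units; beyond the scatter) in this assay and so marks a large weakening of inhibition. Compounds 1 and 2 differ in more than one place, so their gap could not be assigned to any single change, whereas this pair ties a large loss directly to the aromatic end group and shows that the potency of compound 2 depends strongly on what sits there. No measurement shown here explains why this exchange has so large an effect.

The exchange alters both the substituent and its numbered ring position, and compounds 2 and 3 alone cannot separate these two differences; a 4-chlorophenyl or a 2-nitrophenyl group at the same place would be needed to tell them apart. Also open, going by these compounds, is how other end groups would behave on this chain, such as a phenyl ring carrying an amine or a carboxylic acid, so these two results do not yet define a trend for this position.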